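Removing the Ring Carbonyl from Compound 1

This account rests on a few compounds, and the source may have more. Where it says the series, first, only, none or still open, it means among the compounds named here.

Compound 1 `CN1CCC(c2ccc3c(c2)oc(=O)n3C(=O)NCCCCc2ccccc2)CC1=O` holds the second highest of three numbers in an ADME assay on a cell-free system (plasma, Mus musculus) for metabolic stability, read by LC-MS, tested at 2 uM (on this read-out higher numbers stand for a longer-lived compound and lower numbers for a shorter-lived compound), where compound 1 gives 0.6 h. Compound 2 `CN1CCN(c2ccc3c(c2)oc(=O)n3C(=O)NCCCCc2ccccc2)C(=O)C1` gives 0.333 h, and compound 3 `CC(C)CN1CCC(c2ccc3c(c2)oc(=O)n3C(=O)NCCCCc2ccccc2)CC1` gives 1 h. Both steps from compound 1 stay within the scatter: a 1.8-fold lower number from compound 1 to compound 2 (0.26 log units; within the scatter) and a 1.7-fold higher number from compound 1 to compound 3 (0.22 log units; within the scatter). Compound 4 `CN1CCC(c2ccc3c(c2)oc(=O)n3C(=O)NCCCCc2ccccc2)CC1` differs from compound 1 in one place: 1-methylpiperidin-4-yl in place of 1-methyl-2-oxopiperidin-4-yl on an aromatic carbon. The step to compound 3 bears most closely on this change, as that change also put a 1-isobutylpiperidin-4-yl group, lacking the carbonyl, in place of 1-methyl-2-oxopiperidin-4-yl, and it moved the number only within the scatter. A similarly small upward shift, or none beyond the scatter, is therefore expected, a 1.3-fold higher number from compound 1 to compound 4 (0.12 log units; within the scatter). Compound 4 is estimated at 0.8 h, with a range from 0.4 h to 1.6 h.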

Compound 4, half-life: 0.833 h
The estimate for compound 4 lay 1.0-fold (0.02 log units) below the measured number; the measured number falls inside the stated range.
By their numbers in this assay, from the lowest: compounds 2, 1, 4 and 3 (each within the scatter of the next, the first and the last beyond it).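

In this assay, removing the ring carbonyl at this aromatic carbon gives a 1.4-fold higher number from compound 1 to compound 4 (0.14 log units; within the scatter) and so leaves the half-life unresolved from compound 1. Hydrogen in place of isopropyl on the chain carbon bound to the ring amine nitrogen gives a 1.2-fold lower number from compound 3 to compound 4 (0.08 log units; within the scatter) and is equally small, whereas a 2.5-fold higher number from compound 2 to compound 4 (0.40 log units; beyond the scatter) is a modest step that extends the gap seen with the 4-methyl-2-oxopiperazin-1-yl group beyond compound 3 to a second piperidine. As far as these compounds go, whether a carboxylic acid or a longer chain on the ring nitrogen would shift the half-life remains open. No measured evidence offers a reason for these numbers.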